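The compounds below may be only part of what the source reports. "The series", "measured", "known", "first", "only" and "open" are said of these compounds alone.

Three compounds sharing one core were measured in a functional assay on the whole organism with Mus musculus as the target, with a stated time of 30 min; a higher number here means that more compound is needed for the effect, a lower number that less compound is needed. Compound 1 `CC(C)S(=O)(=O)NC1CCCN(S(=O)(=O)c2ccc(F)cc2)C1` gives 1 mg/kg in this assay. Compound 2 `CC(=O)NC1CCN(S(=O)(=O)c2ccc(F)cc2)CC1` gives 0.01 mg/kg in this assay, and compound 3 `CC(=O)N1CCN(S(=O)(=O)c2ccc(F)cc2)CC1` gives 0.01 mg/kg in this assay. Compound 3 therefore stands level with compound 2 at the digits reported, and the two of them together give the lowest of the three numbers, while compound 1 stands much higher, well beyond the usual scatter of such measurements. No two of the measured compounds differ in only one place, so no single structural step can be read directly from the measured set.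

Compound 4 `CCC(=O)N1CCN(S(=O)(=O)c2ccc(F)cc2)CC1` has not yet been measured in this assay. It differs from compound 3 in one place: methyl in place of hydrogen on a saturated chain carbon bound to a carbonyl carbon. The acetyl of compound 3 becomes a propanoyl in compound 4.

Going by the values given here, since the measured compounds offer no comparable step, the expectation rests on the small size of the addition, with one carbon entering and nothing else changing. The step of a 2.0-fold higher number from compound 3 to compound 4 (0.30 log units; within the scatter) that this estimate means is expected to be small, if anything toward a somewhat higher number, and may well lie within the scatter. In this assay compound 4 is estimated at 0.02 mg/kg, with a range from 0.005 mg/kg to 0.1 mg/kg.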

Compound 4, minimum effective dose: 0.01 mg/kg
The estimate for compound 4 lay 2.0-fold (0.30 log units) above the measured number; low and high end bracket the measured number.
By their numbers in this assay, from the lowest: compounds 2, 3 and 4 (each within the scatter of the next); then compound 1.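

In this assay, methyl in place of hydrogen on a saturated chain carbon bound to a carbonyl carbon, which turns the acetyl of compound 3 into the propanoyl of compound 4, gives no change at the digits printed from compound 3 to compound 4 (within the scatter). Going by these compounds alone, this is the first direct reading of a single structural change in this set, as the earlier compounds offered no pair differing in only one place, and it shows that this position can take the change from methyl to ethyl without a change in the minimum effective dose that stands out from the scatter, though it speaks for this one step and this one pair alone. No measured property of these compounds is available to account for this result.

Still open, as far as these compounds go, is whether the number would stay level with a longer chain such as butanoyl, with a branched chain such as isobutyryl, or with an amine or a carboxylic acid at the end of the chain. Also open, from the compounds shown here alone, is whether the same methyl would give the same result on the acetyl of compound 2, where the carbonyl belongs to a different amide.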